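A few compounds are considered here, and "the series" means these few. Any claim that something is new, unique, unknown or untested is made for them only; others in the source may bear on it.

Measured compounds:
Compound 1 `Cc1nc(-c2ccc(Cl)cc2)sc1C(=O)CSc1nc(N)c(C#N)c(-c2ccc(Cl)cc2)n1` gives 46.1% in a functional assay on U-87MG ATCC cells for antiproliferative activity against U-87 MG (Homo sapiens), read by MTT assay, with a stated time of 48 h, tested at 5 uM; a lower number here means a stronger effect, a higher number a weaker effect of the compound at the concentration tested.
Compound 2 `Cc1nc(-c2ccc(Cl)cc2)sc1C(=O)CSc1nc(-c2ccccc2)c(C#N)c(=O)[nH]1` gives 88.9% in this assay.

Of the two numbers in this assay, compound 1 stands lowest; compound 2 sits well above it, and the gap between them is beyond the usual scatter. Among the measured compounds shown here, compound 1 and compound 2 differ at several places at once, so no single step between them can be read.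

The step taken here leads from compound 1 to compound 3 `COc1ccc(-c2nc(C)c(C(=O)CSc3nc(N)c(C#N)c(-c4ccc(Cl)cc4)n3)s2)cc1`, which has not yet been measured in this assay. The change is methoxy in place of chloro on an aromatic carbon. It sits on the aromatic ring attached to the shared core, para to a large group, while the nitrile-bearing ring and its 4-chlorophenyl stay as they are. For the measured compounds named here, no measured pair shows the effect of this change, so any expectation rests on compound 1 alone.

The step is expected to be small, within or only just beyond the scatter, a number 5.9 percentage points higher from compound 1 to compound 3 (within the scatter), leaning slightly toward a weaker effect. Compound 3 is therefore estimated at 52%, with a range from 35% to 72%.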

Compound 3, a percentage reported as activity, at one concentration (the size of the read-out at that concentration, not a potency): 51.4%
Estimate against measurement, compound 3: 0.6 percentage points above; measured number inside the range.
By their numbers in this assay, from the lowest: compounds 1 and 3 (each within the scatter of the next); then compound 2.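

In this assay, among the compounds shown here, the change from 4-chlorophenyl to 4-methoxyphenyl gives a number 5.3 percentage points higher from compound 1 to compound 3 (within the scatter), the first step that can be read at this position. On this aromatic carbon, para to a large group, methoxy and chloro therefore cannot be told apart by this read-out, while the nitrile-bearing ring and its 4-chlorophenyl stay as they are. This rests on a single pair, and nothing available here explains the result.

The compounds shown leave open whether an amine, a hydroxyl or a longer chain such as ethoxy at this position would also stay within the scatter of compound 1. They also leave open whether compound 1 and compound 3 would still read alike at other concentrations, since only one was tested.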